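A few compounds are considered here, and "the series" means these few. Any claim that something is new, unique, unknown or untested is made for them only; others in the source may bear on it.

For the measured compounds named here, in an ADME assay on microsomes from liver (Rattus norvegicus) for metabolic stability, with a stated time of 60 min, tested at 1 uM (a lower number here means that less of the compound is left, a higher number that more of the compound is left), compound 1 `COc1cc(-c2cnn3cc(OC)c(-c4cnn(C)c4)nc23)ccn1` gives 56%, the higher of the two numbers measured so far. Going by the values given here, the only other measured compound, compound 2 `COc1cc(-c2cnn3cc(OC)c(C4CCOC4)nc23)ccn1`, gives 34%. Among the compounds with values here, the one measured step is a number 22 percentage points lower from compound 1 to compound 2 (beyond the scatter), and in it oxolan-3-yl stands in place of 1-methyl-1H-pyrazol-4-yl on an aromatic carbon.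

Compound 3 `COc1cn2ncc(-c3ccnc(OC(C)C)c3)c2nc1-c1cnn(C)c1` keeps the 1-methyl-1H-pyrazol-4-yl group and differs from compound 1 elsewhere: isopropyl in place of methyl on an oxygen on an aromatic ring, so methoxy becomes isopropoxy (isopropyl in place of methyl on an oxygen on an aromatic ring). Within the data shown here, no measured step touches this place, so the step to compound 2 is only a rough guide to how far a single change can move this assay. With compound 1 at 56%, the top of the small measured range, a modest fall seems the more likely outcome, though the data cannot settle the direction. The expected change, somewhat smaller than the measured step, is a number 14 percentage points lower from compound 1 to compound 3 (beyond the scatter). The estimate for compound 3 is 42%, with an expected range from 24% to 60%.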

Compound 3, percent of the compound remaining: 50%
Compound 3: the middle estimate sits 8 percentage points below what was measured; the range from low to high includes it.
By their numbers in this assay, from the lowest: compound 2; then compounds 3 and 1 (each within the scatter of the next).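

In this assay, for the compounds shown here, this is the first reading at this place, on an oxygen on an aromatic ring, and going from methoxy to isopropoxy gives a number 6 percentage points lower from compound 1 to compound 3 (within the scatter), so the two compounds cannot be told apart in this assay. The earlier compounds shown here showed only that replacing 1-methyl-1H-pyrazol-4-yl with oxolan-3-yl gives a number 22 percentage points lower from compound 1 to compound 2 (beyond the scatter); they said nothing about this oxygen, which now appears able to carry isopropyl in place of methyl without a shift beyond the usual scatter. No measurement shown here offers an explanation for this result.

From the compounds shown here alone, one pair speaks for this place, so it remains open whether a longer chain, a cyclopropyl group or a chain ending in an amine on the same oxygen would also leave the percentage remaining within the scatter. Going by these compounds, it is equally open whether isopropoxy would behave the same way alongside oxolan-3-yl, since the two changes appear here only separately and never together in one compound.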